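Trading the Furanyl Ethenyl Arm for a Methyl

The source may report more compounds than this note shows. Statements on the series, on what has been measured and on what is new or still open speak of the compounds shown alone.

Compound 2 `C=C1CC[C@H]2C(C)(C)CCC[C@]2(C)[C@H]1/C=C/c1ccoc1` was tested in a functional assay on HL-60 cells (Homo sapiens) for cytotoxicity, read by MTT assay (on this read-out higher numbers stand for weaker inhibition and lower numbers for stronger inhibition), and gave 31200 nM. Compound 1 `CC1(C)CCC[C@]2(C)[C@@H](/C=C/c3ccoc3)C(CO)=CC(=O)[C@@H]12` gave 36400 nM in this assay; the two numbers lie within the usual scatter of each other, so neither compound can be called the stronger, and both inhibit the cells only weakly. Compound 3 `C=C1CC[C@H]2C(C)(C)CCC[C@]2(C)[C@H]1C` has not yet been measured. It differs from compound 2 in one place: methyl in place of 2-(furan-3-yl)ethenyl on a saturated ring carbon. Within the data shown here, with no measured step to lean on, the expected change a 1.9-fold higher number from compound 2 to compound 3 (0.28 log units; within the scatter) is toward a higher number, likely beyond the scatter. Compound 3 is expected to give about 60000 nM, somewhere between 20000 nM and 200000 nM.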

Compound 3, half-maximal inhibitory concentration: "not active" (no number reported)
Compound 3: no number reported, so the estimate cannot be set against anything.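

Compound 3 is reported as not active, with no number, and no step from compound 2 can be read from that; no evidence on hand explains the result. As far as these compounds go, how much the 2-(furan-3-yl)ethenyl arm contributes to cytotoxicity remains open.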